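A few compounds are considered here, and "the series" means these few. Any claim that something is new, unique, unknown or untested is made for them only; others in the source may bear on it.

Measured in a functional assay on SK-OV-3 cells (Homo sapiens) for antiproliferative activity, read by MTT assay, with a stated time of 24 h; a higher number here means a weaker inhibitor, a lower number a stronger inhibitor:
compound 1 `COc1ccc(C(=O)/C=C/c2cc(OC)c(OC)c(OC)c2)c2c1C=CC(C)(C)O2` gives 9700 nM.
compound 2 `COc1ccc(/C=C/C(=O)c2ccc(OC)c3c2OC(C)(C)C=C3)c(F)c1` gives 4880 nM.
compound 3 `COc1cc(OC)c(OC)cc1/C=C/C(=O)c1ccc(OC)c2c1OC(C)(C)C=C2` is reported only as a limit of the assay, > 10000 nM.

Of the two numbers in this assay, compound 2 carries the lower one, but compound 1 lies within the scatter of it, so the two cannot be told apart on these data. The line the limit of > 10000 nM in this assay, at which 1 of the 3 values shown sits, marks where compound 3 sits. Compound 4 `COc1ccc(C(=O)/C=C/c2cccs2)c2c1C=CC(C)(C)O2` differs from compound 2 by thiophen-2-yl in place of 2-fluoro-4-methoxyphenyl on a double-bonded chain carbon bound to a double-bonded chain carbon. Going by the values given here, no measured pair carries this change, so its size is open; a small move, not beyond the scatter, is expected here. The expected step in this assay from compound 2 to compound 4 is a 1.3-fold higher number from compound 2 to compound 4 (0.12 log units; within the scatter). Compound 4 is estimated at 6500 nM, with a range from 2500 nM to 15000 nM.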

Compound 4, half-maximal inhibitory concentration: > 10000 nM
Compound 4: only a limit was reported; the forecaster's own chance of this, stated with the estimate: 25%; middle value at least 1.5-fold (0.18 log units) away from the limit.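

Thiophen-2-yl in place of 2-fluoro-4-methoxyphenyl on a double-bonded chain carbon bound to a double-bonded chain carbon gives the first readable step in this assay, an at least 2.0-fold higher number from compound 2 to compound 4 (0.31 log units; beyond the scatter), so this position is not indifferent to the group it carries. The value of compound 4, > 10000 nM, is a limit of the assay. That limit is no longer a single case: the limit of > 10000 nM in this assay, at which 2 of the 4 values shown sit.

On these data alone, how far compound 4 lies past the limit stays open, as does which part of the 2-fluoro-4-methoxyphenyl group matters. As far as these compounds go, whether a pyridin-3-yl or 4-(dimethylamino)phenyl group here would give a lower number is also open.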